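A second methyl on the nitrogen of compound 2

A few compounds are considered here, and "the series" means these few. Any claim that something is new, unique, unknown or untested is made for them only; others in the source may bear on it.

Measured in a functional assay on A549 cells (Homo sapiens), read by MTT assay, with a stated time of 72 h; a lower number here means a stronger inhibitor, a higher number a weaker inhibitor:
Compound 1 `C#Cc1cn([C@@H]2O[C@H](CO)[C@@H](O)[C@H]2O)c2ncnc(OC)c12`: 8160 nM
Compound 2 `C#Cc1cn([C@@H]2O[C@H](CO)[C@@H](O)[C@H]2O)c2ncnc(NC)c12`: > 20000 nM (a limit of the assay, not a number)

Compound 2 has no exact value, only a limit of the assay. For compound 2 the position is the limit of > 20000 nM in this assay, at which 1 of the 2 values shown sits. Compound 3 `C#Cc1cn([C@@H]2O[C@H](CO)[C@@H](O)[C@H]2O)c2ncnc(N(C)C)c12` keeps the shared core and differs at one place: methyl in place of hydrogen on a nitrogen on an aromatic ring. In words, this is methyl in place of hydrogen on a nitrogen on an aromatic ring, or methylamino to dimethylamino.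

For the measured compounds named here, only one measured step bears on this change, and it is a different replacement: an at least 2.4-fold higher number from compound 1 to compound 2 (0.38 log units; beyond the scatter). There, methylamino stands in place of methoxy on an aromatic carbon. Going by the values given here, no measured step shows what a methyl added to this nitrogen does. On the evidence of an at least 2.4-fold higher number from compound 1 to compound 2 (0.38 log units; beyond the scatter), a modest move towards a higher number, or none beyond the scatter, is expected in this assay, and a report of only a limit is quite likely. The expected step is a number no higher from compound 2 to compound 3 (the limit leaves the size open). For compound 3 the estimated value is 20000 nM, with an expected range from 6000 nM to 50000 nM.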

Compound 3, half-maximal inhibitory concentration: 390 nM
Compound 3: the middle estimate sits 51-fold (1.71 log units) above what was measured; the measured number lies below the stated range.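

Methyl in place of hydrogen on a nitrogen on an aromatic ring is the first change shown at this nitrogen, and in this assay it gives an at least 51-fold lower number from compound 2 to compound 3 (1.70 log units; beyond the scatter). From the compounds shown here alone, the value of compound 2 is a limit of the assay and not a number, so the true size of this step stays unknown: the limit of > 20000 nM in this assay, at which 1 of the 3 values shown sits. The position therefore does not respond to a nitrogen in place of an oxygen in one direction only: dimethylamino in place of methoxy on an aromatic carbon gives a 21-fold lower number from compound 1 to compound 3 (1.32 log units; beyond the scatter), whereas methylamino in place of methoxy gives an at least 2.4-fold higher number from compound 1 to compound 2 (0.38 log units; beyond the scatter).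

Going by these compounds, the three compounds carry only methoxy, methylamino and dimethylamino at this position, so it remains open whether the lower number in this assay is particular to two methyl groups on the nitrogen or extends to larger groups there, such as a diethylamino group or a pyrrolidine ring. On these data alone, the unsubstituted amino group also remains open, and with it whether a nitrogen carrying two hydrogens would fall in line with compound 2 or with compound 3.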